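Adding an aromatic chain to compound 3

A few compounds are considered here, and "the series" means these few. Any claim that something is new, unique, unknown or untested is made for them only; others in the source may bear on it.

Compound 1 `COc1ccc(CCCN2CCC(CNC(c3ccccc3)c3ccccc3)CC2)cc1` gives 2800 nM
Compound 2 `COc1ccc(CCCN2CCC(COCc3ccc(Cl)c(Cl)c3)CC2)cc1` gives 200 nM
Compound 3 `CN1CCC(COC(c2ccccc2)c2ccccc2)CC1` gives > 20000 nM (a limit, not a number)

All three compounds were tested in a functional assay on cells (T-cell line, Homo sapiens) for inhibition; a lower number here means a stronger inhibitor, a higher number a weaker inhibitor. Compound 3 has no number there, only the limit > 20000 nM of the assay. Within the data shown here, it is the one compound at the limit of > 20000 nM in this assay, at which 1 of the 3 values shown sits, so its true position is unknown.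

The next compound is compound 4 `Cc1ccc(CCCN2CCC(COC(c3ccccc3)c3ccccc3)CC2)cc1`, which has not yet been measured. It differs from compound 3 by one change: 2-(4-methylphenyl)ethyl in place of hydrogen on a saturated chain carbon bound to an amine nitrogen in a ring. In words, 2-(4-methylphenyl)ethyl replaces hydrogen on a saturated chain carbon bound to an amine nitrogen in a ring. Cut one bond further out, this reads methyl to 3-(4-methylphenyl)propyl.

Among the measured compounds shown here, no measured pair shows this change on its own, so the expectation rests on indirect evidence. Compound 1 also carries a long chain ending in an aromatic ring, and it gives 2800 nM in this assay. Compound 2 carries such a chain too, and it gives 200 nM in this assay. A large step toward stronger inhibition is therefore expected, well beyond the scatter, and the expected size is an at least 20-fold lower number from compound 3 to compound 4 (1.30 log units; beyond the scatter). For compound 4 the estimated value is 1000 nM, with an expected range from 200 nM to 5000 nM.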

Compound 4, half-maximal inhibitory concentration: 200 nM
The estimate for compound 4 lay 5.0-fold (0.70 log units) above the measured number; the range from low to high includes it.
By their numbers in this assay, from the lowest: compounds 2 and 4 (each within the scatter of the next); then compound 1. At a limit, above all of these: compound 3.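

In this assay, placing 2-(4-methylphenyl)ethyl in place of hydrogen on a saturated chain carbon bound to an amine nitrogen in a ring gives an at least 100-fold lower number from compound 3 to compound 4 (2.00 log units; beyond the scatter). Among these compounds, this is the first direct reading of the change at this position, since the rest of the molecule stays the same across the pair, whereas the earlier compounds carried a long aromatic chain only alongside other differences from compound 3. The step marks a lower bound on the effect of the change, and its true size stays unknown because compound 3 sits at a limit: the limit of > 20000 nM in this assay, at which 1 of the 4 values shown sits.

The compounds shown leave open whether the gain depends on the length of the chain, as a benzyl group, a 2-phenylethyl group or a longer chain on the same nitrogen would test. They also leave open what the methyl on the aromatic ring contributes, which a plain 3-phenylpropyl chain would address, and whether a carboxylic acid or an amine at the end of the chain would be tolerated.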